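Swapping Methoxy for Fluoro on the Sulfonyl Aryl Ring

The compounds below may be only part of what the source reports. "The series", "measured", "known", "first", "only" and "open" are said of these compounds alone.

Of the compounds shown here, three sharing one core have been measured in a functional assay on K562 cells (Homo sapiens) for inhibition, read by trypan blue exclusion, with a stated time of 72 h; on this read-out lower numbers stand for stronger inhibition and higher numbers for weaker inhibition. Compound 3 `COc1ccc(S(=O)(=O)c2cc3cnc(Nc4ccc5[nH]ccc5c4)nc3n(C)c2=O)cc1` gives 300 nM, the lowest number of the three. Within the data shown here, compound 1 `Cn1c(=O)c(S(=O)(=O)c2ccc(F)cc2)cc2cnc(Nc3cccc4[nH]ccc34)nc21` gives 750 nM, and compound 2 `Cn1c(=O)c(S(=O)(=O)c2ccc(F)cc2)cc2cnc(Nc3ccc4[nH]ncc4c3)nc21` gives 10000 nM; the only single-point step measured, a 13-fold higher number from compound 1 to compound 2 (1.12 log units; beyond the scatter), concerns the group on a nitrogen on an aromatic ring, not the sulfonyl side. Compound 4 `Cn1c(=O)c(S(=O)(=O)c2ccc(F)cc2)cc2cnc(Nc3ccc4[nH]ccc4c3)nc21` differs from compound 3 by fluoro in place of methoxy on an aromatic carbon. Among the measured compounds shown here, no measured step covers this exchange, so nothing here sets its size or direction; the expectation is therefore a step of a 1.7-fold higher number from compound 3 to compound 4 (0.22 log units; within the scatter), within the usual scatter. On that basis compound 4 is expected to give about 500 nM, most likely between 200 nM and 1500 nM.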

Compound 4, half-maximal inhibitory concentration: 200 nM
For compound 4 the middle estimate is 2.5-fold (0.40 log units) above the measured one; the range from low to high includes it.
By their numbers in this assay, from the lowest: compounds 4 and 3 (each within the scatter of the next); then compound 1; then compound 2.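

Fluoro in place of methoxy on this aromatic carbon gives a 1.5-fold lower number from compound 3 to compound 4 (0.18 log units; within the scatter) in this assay and so leaves the two groups indistinguishable here. With fluoro held constant, the group on the nitrogen matters far more: 1H-indol-5-yl in place of 1H-indazol-5-yl gives a 50-fold lower number from compound 2 to compound 4 (1.70 log units; beyond the scatter) and in place of 1H-indol-4-yl gives a 3.8-fold lower number from compound 1 to compound 4 (0.57 log units; beyond the scatter) on the same fluoro-bearing scaffold. No measurement given here accounts for these differences. On these data alone, how an amine, a carboxylic acid or a longer chain would behave on this aromatic carbon remains open, as does whether methoxy compounds would follow the same order across the nitrogen groups.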